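This account rests on a few compounds, and the source may have more. Where it says the series, first, only, none or still open, it means among the compounds named here.

Measured in a functional assay on SW-620 cells (Homo sapiens) for cytotoxicity, read by MTT assay, with stated times of 4 h and 72 h, tested at 2 uM; a higher number here means a weaker inhibitor, a lower number a stronger inhibitor:
- compound 1 `Cc1ccc(/C=C/C(=O)c2ccc(Nc3cc(C)nc4nc(SCc5nc6ccccc6[nH]5)nn34)cc2)cc1` gives 1520 nM
- compound 2 `Cc1cc(Nc2ccc(C(=O)/C=C/c3ccc(Cl)cc3)cc2)n2nc(SCc3nc4ccccc4[nH]3)nc2n1` gives 230 nM

Compound 2, at 230 nM, holds the lower of the two numbers in this assay. Compound 3 `Cc1cc(Nc2ccc(C(=O)/C=C/c3ccccc3F)cc2)n2nc(SCc3nc4ccccc4[nH]3)nc2n1` departs from it by 2-fluorophenyl in place of 4-chlorophenyl on a double-bonded chain carbon bound to a double-bonded chain carbon, placing 2-fluorophenyl where 4-chlorophenyl stood. Among the compounds with values here, only one measured step bears on this, the modest 6.6-fold lower number from compound 1 to compound 2 (0.82 log units; beyond the scatter), where chloro replaced methyl on an aromatic carbon. Within the data shown here, no measured compound carries fluorine, so that step is only a loose guide, and a modest rise in the number is expected. The expected change is a 2.4-fold higher number from compound 2 to compound 3 (0.38 log units; beyond the scatter). For compound 3 the estimated value is 550 nM, with an expected range of 180 nM to 1700 nM.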

Compound 3, half-maximal inhibitory concentration: 250 nM
Estimate against measurement, compound 3: 2.2-fold (0.34 log units) above, within the range that was stated.
By their numbers in this assay, from the lowest: compounds 2 and 3 (each within the scatter of the next); then compound 1.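

In this assay, 2-fluorophenyl in place of 4-chlorophenyl on a double-bonded chain carbon bound to a double-bonded chain carbon gives a 1.1-fold higher number from compound 2 to compound 3 (0.04 log units; within the scatter) and so leaves the two groups unseparated here. In place of 4-methylphenyl, the same group gives a 6.1-fold lower number from compound 1 to compound 3 (0.78 log units; beyond the scatter) and so leaves compound 1 apart from the other two. Nothing on hand accounts for these results.

Going by these compounds, because the halogen and its ring position both differ between compound 2 and compound 3, their separate contributions remain open. So does the outcome with a methoxy group or an amine on this phenyl ring.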